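The compounds below may be only part of what the source reports. "The series", "measured", "known", "first", "only" and "open" are said of these compounds alone.

Of the compounds shown here, three on a shared core have been tested in a functional assay on the whole organism (Tail, strain ICR) with Mus musculus as the target, in the tail flick test, with a stated time of 30 min, at a dose of 12.5 umol/kg by the oral route; on this read-out lower numbers stand for a weaker effect and higher numbers for a stronger effect at the one dose given. Compound 1 `O=C(CN(c1nc(Cl)nc2[nH]cnc12)C1CC1)NCC(=O)OCc1ccccc1` gives 11.3%, compound 3 `CC(C)[C@H](NC(=O)CN(c1nc(Cl)nc2[nH]cnc12)C1CC1)C(=O)OCc1ccccc1` gives 16%, and compound 2 `N=C(N)NCCC[C@H](NC(=O)CN(c1nc(Cl)nc2[nH]cnc12)C1CC1)C(=O)O` gives 22.2%, the highest of the three numbers; its gap to compound 3 stays within the scatter, while its gap to compound 1 lies beyond it. Within the data shown here, the only measured step, a number 4.7 percentage points higher from compound 1 to compound 3 (within the scatter), concerns another place on the chain and does not speak to the change now considered. Compound 4 `NCCCC[C@H](NC(=O)CN(c1nc(Cl)nc2[nH]cnc12)C1CC1)C(=O)O` differs from compound 2 by a group of 2 heavy atoms (1 carbon, 1 nitrogen; no ring) in place of a group of 4 heavy atoms (1 carbon, 3 nitrogen; no ring), on a saturated chain carbon, four bonds along the chain from an amide-type nitrogen and a carbonyl carbon. Among the measured compounds shown here, with no step bearing on this change, no shift beyond the scatter is expected, and the step of a number 2.2 percentage points lower from compound 2 to compound 4 (within the scatter) is estimated to be small. Compound 4 is therefore expected to give about 20% in this assay, between 9% and 32%.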

Compound 4, a percentage reported as activity, at one dose (the size of the read-out at that dose, not a potency): 16.3%
For compound 4 the middle estimate is 3.7 percentage points above the measured one; the range from low to high includes it.
By their numbers in this assay, from the lowest: compounds 1, 3, 4 and 2 (each within the scatter of the next, the first and the last beyond it).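

Among these compounds, this is the first measured step at this position: in this assay, the change gives a number 5.9 percentage points lower from compound 2 to compound 4 (within the scatter) on a chain that otherwise stays the same. At this one dose, the read-out therefore does not separate aminomethyl from the group of 4 heavy atoms it replaces. Nothing available explains this result.

The compounds shown leave open whether a carboxylic acid or a hydroxyl group in place of aminomethyl, on this same saturated chain carbon, would give a step beyond the scatter. They also leave open how either group would behave at other doses.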